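The source may report more compounds than this note shows. Statements on the series, on what has been measured and on what is new or still open speak of the compounds shown alone.

The measured compounds:
compound 1, `Cc1cc2occ(-c3nc(-c4ccccc4)c(-c4ccccc4)n3-c3ccc(Cl)c(Cl)c3)c(=O)c2cc1Cl`, gives 12500 nM in a functional assay on HepG2 cells (Homo sapiens) for inhibition, read by MTT assay, with a stated time of 72 h; on this read-out higher numbers stand for weaker inhibition and lower numbers for stronger inhibition;
compound 2, `Cc1ccc(-n2c(-c3coc4cc(C)c(Cl)cc4c3=O)nc(-c3ccccc3)c2-c2ccccc2)c(C)c1`, gives 3120 nM in this assay.

Among the measured compounds shown here, compound 2 holds the lower of the two numbers so far; its only neighbour is compound 1, and the step between them, a 4.0-fold lower number from compound 1 to compound 2 (0.60 log units; beyond the scatter), came from exchanging the group on the aromatic nitrogen. Compound 3, `COc1cccc(-n2c(-c3coc4cc(C)c(Cl)cc4c3=O)nc(-c3ccccc3)c2-c2ccccc2)c1`, has not yet been measured in this assay. It differs from compound 2 at a single place: 3-methoxyphenyl in place of 2,4-dimethylphenyl on an aromatic nitrogen.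

For the measured compounds named here, the one measured step that touches this place is the one from compound 1 to compound 2, which was modest yet clearly beyond the scatter. Going by the values given here, neither of the groups in that step is the one now entering, so that step shows only that changes at this position can move the number by a modest amount in either direction; it gives no firm direction for the present change. A step of modest size, or none beyond the scatter, is therefore expected in this assay, with a somewhat higher number slightly more likely given that compound 2 already sits at the lower end of the two values.

Compound 3 is expected to give 5000 nM, in a range from 1500 nM to 16000 nM, which means an expected step of a 1.6-fold higher number from compound 2 to compound 3 (0.20 log units; within the scatter).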

Compound 3, half-maximal inhibitory concentration: 6250 nM
For compound 3 the middle estimate is 1.3-fold (0.10 log units) below the measured one; the measured number falls inside the stated range.
By their numbers in this assay, from the lowest: compounds 2, 3 and 1 (each within the scatter of the next, the first and the last beyond it).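

In this assay, the 3-methoxyphenyl group on the aromatic nitrogen cannot be told apart from either of the two groups tested before it: the result is a 2.0-fold higher number from compound 2 to compound 3 (0.30 log units; within the scatter) and a 2.0-fold lower number from compound 1 to compound 3 (0.30 log units; within the scatter), and both steps lie within the scatter. The clear step between the 3,4-dichlorophenyl and 2,4-dimethylphenyl groups therefore now has a third member that lies within the scatter of both, so these three substituted phenyl groups do not fall into two separate levels. Bringing in a group with a hydrogen-bond acceptor in place of one without did not produce a step beyond the scatter from compound 2, and no measurement shown accounts for how these groups compare.

The compounds leave open whether a phenyl group carrying an amine or a carboxylic acid on this nitrogen would move the number further than any of the three groups seen so far. They also leave open whether an alkyl chain in place of the phenyl ring at this position would be tolerated at all in this assay.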